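The source may report more compounds than this note shows. Statements on the series, on what has been measured and on what is new or still open speak of the compounds shown alone.

Of the compounds shown here, two with a shared core have numbers so far in a functional assay on A2780 cells (Homo sapiens) for inhibition, read by sulforhodamine B assay, with a stated time of 3 days; on this read-out lower numbers stand for stronger inhibition and higher numbers for weaker inhibition. Compound 1 (`O=C1Nc2ccc(F)cc2/C1=C\C(=O)c1ccc(O)cc1F`) gives 1580 nM, and compound 2 (`O=C1Nc2ccc(F)cc2/C1=C\C(=O)c1ccc(C2CCCCC2)cc1`) gives 2310 nM. These two values lie within the usual scatter of each other, so compound 2 stands level with compound 1. Compound 3 (`O=C1Nc2ccc([N+](=O)[O-])cc2/C1=C\C(=O)c1ccc(C2CCCCC2)cc1`) has not yet been measured in this assay. It departs from compound 2 in one place, with nitro in place of fluoro on an aromatic carbon. Within the data shown here, no measured pair shows this exchange, so the data give no direct guide to its size or direction. Among the measured compounds shown here, the only close reference is compound 2 at 2310 nM, and no change beyond the scatter is expected, with a wide margin on either side. The expected step, a 1.3-fold lower number from compound 2 to compound 3 (0.11 log units; within the scatter), is an estimate that stays within the scatter. The estimated value for compound 3 is 1800 nM, with an expected range of 600 nM to 5500 nM.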

Compound 3, half-maximal inhibitory concentration: 2090 nM
Compound 3: the middle estimate sits 1.2-fold (0.06 log units) below what was measured; the range from low to high includes it.
By their numbers in this assay, from the lowest: compounds 1, 3 and 2 (each within the scatter of the next).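

In this assay, among these compounds, nitro in place of fluoro on this aromatic carbon gives a 1.1-fold lower number from compound 2 to compound 3 (0.04 log units; within the scatter), the first direct reading of an exchange at this position. Nitro brings 3 heavy atoms and 2 hydrogen-bond acceptors where fluoro brings 1 heavy atom and no acceptor, yet compound 3 stands level with compound 2, so with the rest of the molecule held fixed, this position accepts both groups without a change beyond the scatter. No measurement here bears on why the two groups read alike.

On these data alone, it remains open whether an amine, a carboxylic acid or a methoxy group on this carbon would also stay level with fluoro and nitro. As far as these compounds go, it is also open whether the same exchange would read alike with a substituent other than cyclohexyl on the far aromatic ring.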